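Aryl substituent changes on a shared thiazolopyridine-free core

A few compounds are considered here, and "the series" means these few. Any claim that something is new, unique, unknown or untested is made for them only; others in the source may bear on it.

Within the data shown here, in a functional assay on HCT-116 cells (Homo sapiens) for inhibition, read by MTT assay, with a stated time of 48 h, tested at 1 mg/mL (on this read-out higher numbers stand for more inhibition at the one concentration tested (going by the name of the read-out) and lower numbers for less inhibition), compound 2 `N#CC1=C(N)N2C(=O)CSC2=C(C#N)C1c1ccccc1` gives 50.8%; the only other number, that of compound 1 `N#CC1=C(N)N2C(=O)CSC2=C(C#N)C1c1ccccc1Cl` at 54.1% in this assay, lies within the scatter of it, so compound 2 holds no separate place on these two numbers. Compound 3 `Cc1ccc(C2C(C#N)=C(N)N3C(=O)CSC3=C2C#N)cc1` differs from compound 2 by methyl in place of hydrogen on an aromatic carbon. Among the measured compounds shown here, the one measured step on the same ring, a number 3.3 percentage points lower from compound 1 to compound 2 (within the scatter), bears on this change and stayed within the scatter. The expected step is therefore a number 0.2 percentage points higher from compound 2 to compound 3 (within the scatter), none beyond the scatter. Compound 3 is estimated at 51%, expected range 40% to 62%.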

Compound 3, a percentage reported as inhibition, at one concentration (the size of the read-out at that concentration, not a potency): 47.4%
Estimate against measurement, compound 3: 3.6 percentage points above; the range from low to high includes it.
By their numbers in this assay, from the lowest: compounds 3, 2 and 1 (each within the scatter of the next).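

Phenyl to 4-methylphenyl gives a number 3.4 percentage points lower from compound 2 to compound 3 (within the scatter) in this assay, so methyl on this aromatic carbon, para to a large group, does not separate from hydrogen. Replacing 2-chlorophenyl with 4-methylphenyl gives a number 6.7 percentage points lower from compound 1 to compound 3 (within the scatter), so this wider aryl change also stays unresolved, and all three aryl groups sit within the scatter of one another. No measurement bears on why these numbers lie so close. As far as these compounds go, whether an amine, a carboxylic acid or a longer alkyl chain on the same ring would move the number beyond the scatter remains open.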